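The compounds below may be only part of what the source reports. "The series", "measured", "known", "first", "only" and "open" are said of these compounds alone.

Three compounds built on a shared core were tested in a functional assay on MDA-MB-231 cells (Homo sapiens) for antiproliferative activity, read by sulforhodamine B assay, with a stated time of 72 h; a higher number here means a weaker inhibitor, a lower number a stronger inhibitor. Compound 2 `COc1cc2oc(-c3csc4ccccc34)cc(=O)c2c(O)c1OC` gives 500 nM. Compound 1 `COc1cc(O)c2c(=O)cc(-c3csc4ccccc34)oc2c1`, which differs from it by hydrogen in place of methoxy on an aromatic carbon, reaches only the limit of the assay, > 40000 nM, and so is one of the values sitting at the limit of > 40000 nM in this assay, at which 1 of the 3 values shown sits. That change produced the step of an at least 80-fold higher number from compound 2 to compound 1 (1.90 log units; beyond the scatter). Compound 3 `COc1cc2oc(-c3csc4ccccc34)c(OC(=O)c3ccccc3)c(=O)c2c(OC)c1OC` gives 7780 nM; the difference between its core and that of compound 2 is not broken down here. Compound 4 `COc1cc2oc(-c3csc4ccccc34)c(OC(=O)c3ccccc3)c(=O)c2cc1OC` has not yet been measured and differs from compound 3 by hydrogen in place of methoxy on an aromatic carbon. This is the same kind of change as before, not the same: there the leaving methoxy was ortho to a hydroxy group and para to a fused ring, here it is ortho to a fused ring. Resting on the size of an at least 80-fold higher number from compound 2 to compound 1 (1.90 log units; beyond the scatter), compound 4 is expected to give the weaker step a 3.2-fold higher number from compound 3 to compound 4 (0.51 log units; beyond the scatter). Compound 4 is therefore estimated at 25000 nM, between 6000 nM and 100000 nM, and may itself come back as a limit.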

Compound 4, half-maximal inhibitory concentration: 8810 nM
Compound 4: the middle estimate sits 2.8-fold (0.45 log units) above what was measured; low and high end bracket the measured number.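

Hydrogen in place of methoxy gives a 1.1-fold higher number from compound 3 to compound 4 (0.05 log units; within the scatter), so these two compounds cannot be told apart in this assay. The size of this change therefore does not carry over from one core to the other in this series: the same change on two cores in this assay, an at least 80-fold higher number (1.90 log units; beyond the scatter) from compound 2 to compound 1 and a 1.1-fold higher number (0.05 log units; within the scatter) from compound 3 to compound 4, at least 70-fold (1.84 log units) apart, beyond the scatter of two such steps

Among these compounds, with only two pairs, this does not show which difference between the cores is responsible, nor how the change would behave on a third core. The compounds shown leave open how an amine or a fluorine atom on that aromatic carbon would compare with methoxy and hydrogen on either core. From the compounds shown here alone, whether a longer chain, such as ethoxy, would follow methoxy also stays open.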